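The compounds below may be only part of what the source reports. "The series", "measured", "known", "first", "only" and "open" are said of these compounds alone.

In a functional assay on VCaP cells (Homo sapiens) for antiproliferative activity, read by CCK-8 assay, with a stated time of 6 days (a higher number here means a weaker inhibitor, a lower number a stronger inhibitor), compound 1 `CC(=O)c1cc(C(=O)N[C@H](C)Cn2ccc(-c3cc(F)c(C#N)c(Cl)c3)n2)n[nH]1` has no number, and its entry reads "not determined" (no result reported). Compound 2 `COc1ccc(C(=O)N[C@@H](C)Cn2ccc(-c3ccc(C#N)c(Cl)c3)n2)cc1` gives 1540 nM and compound 3 `C[C@@H](Cn1ccc(-c2ccc(C#N)c(Cl)c2)n1)NC(=O)c1ccccc1F` gives 2190 nM, so these two stand within the scatter of each other. Among the compounds with values here, the only measured step, a 1.4-fold higher number from compound 2 to compound 3 (0.15 log units; within the scatter), exchanges one group on a carbonyl carbon and stays inside that scatter.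

Compound 4 `C[C@@H](Cn1ccc(-c2ccc(C#N)c(Cl)c2)n1)Nc1cccnc1` departs from compound 3 in a different way: pyridin-3-yl in place of (2-fluorophenyl)carbonyl on an amine nitrogen. Put in words, pyridin-3-yl stands in place of (2-fluorophenyl)carbonyl on an amine nitrogen, so the carbonyl is lost. Within the data shown here, no measured step removes a carbonyl, and the small step from a 1.4-fold higher number from compound 2 to compound 3 (0.15 log units; within the scatter) therefore offers only weak guidance. A modest move toward weaker inhibition is expected, starting from compound 3 at 2190 nM, with wide uncertainty in either direction. The estimated change in this assay is a 1.6-fold higher number from compound 3 to compound 4 (0.20 log units; within the scatter). For compound 4 the estimated value is 3500 nM, with an expected range from 1000 nM to 12000 nM.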

Compound 4, half-maximal inhibitory concentration: > 30000 nM
Compound 4: no number, only a limit (the forecaster's own chance of this, stated with the estimate: 15%); middle value at least 8.5-fold (0.93 log units) away from the limit.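

Within the data shown here, on the amine nitrogen, the only earlier step changed one group on a carbonyl carbon and stayed within the scatter, whereas pyridin-3-yl in place of (2-fluorophenyl)carbonyl removes the carbonyl and gives a large change in this assay, namely an at least 13-fold higher number from compound 3 to compound 4 (1.13 log units; beyond the scatter). Both groups carry one six-membered aromatic ring and the same hydrogen-bond counts, so an aromatic ring with those counts on this nitrogen is not enough to keep compound 4 within the scatter of compound 3. The entry for compound 4 is a limit and not a number: the limit of > 30000 nM in this assay, at which 1 of the 4 values shown sits.

The compounds shown do not separate the loss of the carbonyl from the arrival of the ring nitrogen of pyridin-3-yl. From the compounds shown here alone, how a pyridin-3-ylcarbonyl group or a plain phenyl on this amine nitrogen would read stays open.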